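A few compounds are considered here, and "the series" means these few. Any claim that something is new, unique, unknown or untested is made for them only; others in the source may bear on it.

Going by the values given here, compound 2 `Cc1ccc(NC(=S)NC(=O)c2cn(-c3ccccc3)nc2-c2ccc(C)cc2)cc1` gives 5660 nM in a functional assay on MCF7 cells (Homo sapiens) for inhibition, read by CCK-8 assay, with a stated time of 48 h (on this read-out lower numbers stand for stronger inhibition and higher numbers for weaker inhibition), one of only two numbers, the other belonging to compound 1 `Cc1ccc(NC(=S)NC(=O)c2cn(-c3ccccc3)nc2-c2ccc(Cl)cc2)cc1`, which gives 5980 nM, within the scatter of compound 2. Among the compounds with values here, the single measured step, a 1.1-fold lower number from compound 1 to compound 2 (0.02 log units; within the scatter), exchanged the group at the same place that changes next and did not move this assay beyond the scatter. Compound 3 `Cc1ccc(NC(=S)NC(=O)c2cn(-c3ccccc3)nc2-c2ccccc2)cc1` differs from compound 2 by hydrogen in place of methyl on an aromatic carbon. Within the data shown here, with only that indifferent step as a guide, no shift beyond the scatter is expected in this assay. Compound 3 is therefore estimated at 6300 nM, a step of a 1.1-fold higher number from compound 2 to compound 3 (0.05 log units; within the scatter), with a range from 2800 nM to 14000 nM.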

Compound 3, half-maximal inhibitory concentration: 5900 nM
Estimate against measurement, compound 3: 1.1-fold (0.03 log units) above; the measured number falls inside the stated range.
By their numbers in this assay, from the lowest: compounds 2, 3 and 1 (each within the scatter of the next).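

With hydrogen at this place, on an aromatic carbon para to a large group, the series gains its unsubstituted reference, and in this assay the change from 4-methylphenyl to phenyl gives a 1.0-fold higher number from compound 2 to compound 3 (0.02 log units; within the scatter) while hydrogen in place of chloro gives a 1.0-fold lower number from compound 1 to compound 3 (0.01 log units; within the scatter) as the second step. Hydrogen, methyl and chloro at this place are therefore not told apart by this read-out. No measurement on hand accounts for this indifference. Still open, as far as these compounds go, is whether an amine, a carboxylic acid or a longer chain at this place would give a step beyond the scatter. Also open, from the compounds shown here alone, is whether changes elsewhere on the shared core would do so.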